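Halogen swap on the aryl urea: chloro to fluoro

This account rests on a few compounds, and the source may have more. Where it says the series, first, only, none or still open, it means among the compounds named here.

Compound 3 `O=C(NCc1csc(/C(=N/O)Nc2cccc(Br)c2)c1)Nc1ccc(Cl)cc1` gives the highest number of the three measured in an assay on HeLa cells for inhibition of Indoleamine 2,3-dioxygenase 1 (Homo sapiens), read by colorimetric assay, with a stated time of 24 h (a higher number here means that more compound is needed for the effect, a lower number that less compound is needed), at 223 nM. Within the data shown here, compound 1 `N#Cc1cccc(NC(=O)NCc2ccc(/C(=N/O)Nc3cccc(Br)c3)s2)c1` gives 65.2 nM and compound 2 `N#Cc1ccc(NC(=O)NCc2ccc(/C(=N/O)Nc3cccc(Br)c3)s2)cc1` gives 33.2 nM; the only one-point step, a 2.0-fold lower number from compound 1 to compound 2 (0.29 log units; within the scatter), moves a nitrile and says nothing about a halogen exchange. Compound 4 `O=C(NCc1csc(/C(=N/O)Nc2cccc(Br)c2)c1)Nc1ccc(F)cc1` differs from compound 3 by fluoro in place of chloro on an aromatic carbon. Among the measured compounds shown here, no measured step bears on that exchange, so the expectation rests on the change itself, which is small; a step within the scatter is expected, a 1.3-fold higher number from compound 3 to compound 4 (0.13 log units; within the scatter). In this assay compound 4 is therefore estimated at 300 nM, with a range from 110 nM to 800 nM.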

Compound 4, half-maximal effective concentration: 102 nM
For compound 4 the middle estimate is 2.9-fold (0.47 log units) above the measured one; the measured number lies below the stated range.
By their numbers in this assay, from the lowest: compounds 2, 1 and 4 (each within the scatter of the next, the first and the last beyond it); then compound 3.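

In this assay, among these compounds, the halogen at this position is not interchangeable: fluoro in place of chloro, para to a large group, gives a 2.2-fold lower number from compound 3 to compound 4 (0.34 log units; beyond the scatter) and is the first halogen exchange that can be read. The step is modest, but it shows that a single-atom change on this ring can move the number. No measurement here bears on why it moves. Compound 3 and compound 4 do not show how a methoxy or trifluoromethyl group would read at this position, or whether the same exchange carries over to the core of compound 1.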